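Swapping the Acyl Group on a Chemokine Receptor Ligand

The compounds below may be only part of what the source reports. "The series", "measured", "known", "first", "only" and "open" are said of these compounds alone.

Measured compounds:
compound 1 `O=C(NCc1ccc(CNS(=O)(=O)c2ccc3c(c2)CCO3)cc1)c1cccc2c1COC2`: 1000 nM
compound 2 `O=C(NCc1ccc(CNS(=O)(=O)c2ccc3c(c2)CCO3)cc1)c1scc2c1OCCO2`: 10 nM

In an assay on cells for displacement of a labelled ligand from C-X-C chemokine receptor type 4 (Homo sapiens), read by fluorescence and microscopy, with stated times of 10 min and 30 min (on this read-out higher numbers stand for an effect only at larger amounts of compound and lower numbers for an effect already at smaller amounts), compound 1 gives 1000 nM, and compound 2 gives 10 nM. For the measured compounds named here, compound 2 therefore stands at the lowest of the two numbers, and the only measured step is a 100-fold lower number from compound 1 to compound 2 (2.00 log units; beyond the scatter), a large change produced by exchanging the group on the carbonyl carbon.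

Compound 3 `Cc1cc(C(=O)NCc2ccc(CNS(=O)(=O)c3ccc4c(c3)CCO4)cc2)n(C)n1` differs from compound 2 at that same carbonyl carbon: a group of 7 heavy atoms (5 carbon, 2 nitrogen; one five-membered aromatic ring with 2 hetero atoms) in place of a group of 9 heavy atoms (6 carbon, 2 oxygen, 1 sulfur; one five-membered aromatic ring with 1 hetero atom, one six-membered non-aromatic ring with 2 hetero atoms), on a carbonyl carbon. Going by the values given here, the one step that bears on this change is a 100-fold lower number from compound 1 to compound 2 (2.00 log units; beyond the scatter), which shows that the group attached to the carbonyl carbon can shift the read-out a great deal. Among the compounds with values here, compound 3 carries neither the group of compound 1 nor the group that gave compound 2 its low number, so the expected direction is towards a higher number, with a wide range since only one comparison exists.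

Compound 3 is expected to give about 300 nM, between 30 nM and 3000 nM. This corresponds to an expected step of a 30-fold higher number from compound 2 to compound 3 (1.48 log units; beyond the scatter).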

Compound 3, effective concentration (reported as EC, without a stated level of effect): 1000 nM
Beside the measured number, compound 3's estimate is 3.3-fold (0.52 log units) below it; the range from low to high includes it.
By their numbers in this assay, from the lowest: compound 2; then compounds 1 and 3 (each within the scatter of the next).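

In this assay the 1,3-dimethyl-1H-pyrazol-5-yl group on the carbonyl carbon brings a 100-fold higher number from compound 2 to compound 3 (2.00 log units; beyond the scatter) and so shows that the low number does not come with just any five-membered aromatic ring at this place. The comparison with the older high-number compound reads no change at the digits printed from compound 1 to compound 3 (within the scatter) even though the two groups differ clearly in make-up, one holding two nitrogens and the other a carbon-only six-membered aromatic ring and one oxygen. Among these three compounds, then, only the group with sulfur and two oxygens stands apart, and no measurement at hand explains this result.

Which part of that group matters stays open, as its sulfur-bearing five-membered aromatic ring and its six-membered non-aromatic ring with two oxygens enter and leave together in these compounds. The compounds shown also do not tell what a plain thiophene ring without the second ring would give on the carbonyl carbon, or how that ring would fare if it carried an amine or a carboxylic acid.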